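From phenyl to cyclohexyl on the amide side chain

A few compounds are considered here, and "the series" means these few. Any claim that something is new, unique, unknown or untested is made for them only; others in the source may bear on it.

Measured in an ADME assay on the whole organism (strain Sprague-Dawley) for pharmacokinetics, with Rattus norvegicus as the target, at a dose of 5 mg/kg by the oral route; a lower number here means that a smaller share of the oral dose reaches the circulation, a higher number that a larger share of the oral dose reaches the circulation:
compound 1 `CC(C)c1ccc2c(Nc3cc(C(=O)N[C@@H](C)c4ccccc4)ccc3Sc3ccc(N)cc3)ncnc2n1`: 42.4%
compound 2 `CC(C)c1ccc2c(Nc3cc(C(=O)N[C@@H](C)c4ccc(Br)cc4)ccc3Sc3ccc(N)cc3)ncnc2n1`: 24.9%

In this assay, compound 1 is the higher of the two, at 42.4%. Compound 3 `CC(C)c1ccc2c(Nc3cc(C(=O)N[C@@H](C)C4CCCCC4)ccc3Sc3ccc(N)cc3)ncnc2n1` has not yet been measured, and its structure differs from that of compound 1 as follows: cyclohexyl in place of phenyl on a saturated chain carbon bound to an amide-type nitrogen and a saturated chain carbon. Among the measured compounds shown here, the only measured step, a number 17.5 percentage points lower from compound 1 to compound 2 (beyond the scatter), is a different change, bromo in place of hydrogen on an aromatic carbon, so it offers only loose guidance. For the measured compounds named here, no measured compound replaces the phenyl itself. The expected step, a number 7.4 percentage points lower from compound 1 to compound 3 (within the scatter), is slightly downward and not beyond the scatter. For compound 3 the estimate is 35%, with an expected range of 15% to 55%.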

Compound 3, oral bioavailability: 5%
Estimate against measurement, compound 3: 30 percentage points above; the whole stated range lies above it.
By their numbers in this assay, from the lowest: compound 3; then compound 2; then compound 1.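

In this assay, among the compounds shown here, the earlier compounds had changed only a substituent on the phenyl, whereas compound 3 replaces the ring itself at this position. With the same count of heavy atoms, the non-aromatic cyclohexyl gives a number 37.4 percentage points lower from compound 1 to compound 3 (beyond the scatter) and, against the brominated ring, a number 19.9 percentage points lower from compound 2 to compound 3 (beyond the scatter), leaving compound 3 the lowest of the three. Nothing shown here explains this drop. Still open, as far as these compounds go, is whether a pyridine ring, a cyclopentyl group or a cyclohexyl bearing an amine at this place would stand nearer compound 1 or compound 3.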